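The source may hold more compounds than are shown below. What is called first, only, known or untested is meant among the compounds shown, and "the series" means these compounds.

Measured compounds:
compound 1, `O=C1CN(Cc2ccc(-c3ccc(C4(C(=O)O)CC4)cc3)cc2)C(=O)N1c1ccccc1`: 1.5 in a physicochemical assay for lipophilicity, read by HPLC, at pH 7.4; on this read-out higher numbers stand for higher lipophilicity and lower numbers for lower lipophilicity
compound 2, `O=C(O)Cc1ccc(-c2ccc(CN3CC(=O)N(C4CCCCC4)C3=O)nc2)cc1`: -0.35 in this assay

Compound 1 has the higher of these two numbers; compound 2 sits a long way below it, well outside the usual scatter of repeated readings in this assay. Compound 3, `O=C(O)Cc1ccc(-c2ccc(CN3CC(=O)N(c4ccccc4)C3=O)cc2)cc1`, has not yet been measured. It differs from compound 1 in one place: carboxymethyl in place of 1-carboxycyclopropyl on an aromatic carbon. Compound 2 also carries a carboxymethyl and gives -0.35, but it differs from compound 1 in other places too, so no direct step can be read from it. Shrinking the group from six heavy atoms to four, with the three-membered ring gone, is expected to lower the number in this assay by a moderate amount, beyond the scatter. The expected step from compound 1 to compound 3 is a number 0.60 log units lower from compound 1 to compound 3 (beyond the scatter). Compound 3 is therefore estimated at 0.9, with a likely range from 0.4 to 1.4.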

Compound 3, distribution coefficient: 2.18
The estimate for compound 3 lay 1.28 log units below the measured number; the measured number lies above the stated range.
By their numbers in this assay, from the lowest: compound 2; then compound 1; then compound 3.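

In this assay, putting carboxymethyl in place of 1-carboxycyclopropyl on this aromatic carbon gives a number 0.68 log units higher from compound 1 to compound 3 (beyond the scatter). At this position, para to a large group, the smaller group without the three-membered ring therefore reads higher, even though the two groups have the same counts of hydrogen-bond donors and acceptors and neither carries a net charge, so a smaller heavy-atom count did not bring a lower number here. Nothing measured in this set accounts for the direction of this step.

From the compounds shown here alone, it remains open how a carboxylic acid set directly on the aromatic carbon, or a longer chain ending in one, would read at this position. This single pair also cannot tell whether the same swap would move the number in the same direction on a different core.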